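Aryl exchange at the saturated ring carbon: compound 4

This account rests on a few compounds, and the source may have more. Where it says the series, first, only, none or still open, it means among the compounds named here.

Measured compounds in a functional assay on HEK293 cells for agonist activity at D(4) dopamine receptor (Homo sapiens), read by FLIPR; a higher number here means that more compound is needed for the effect, a lower number that less compound is needed:
compound 1 `Cc1cccc(C(=O)NCN2CCC(c3nccs3)CC2)c1` gives 9.8 nM
compound 2 `Cc1cccc(NC(=O)CN2CCC(c3nccs3)CC2)c1` gives 1 nM
compound 3 `COc1ccccc1C1CCN(CC(=O)Nc2cccc(C)c2)CC1` gives 420 nM

Compound 3 stands at the highest number of the three; its distance to compound 1 and to compound 2 is in each case beyond the scatter. The next compound in the series is compound 4 `Cc1cccc(NC(=O)CN2CCC(c3cccc(F)c3)CC2)c1`, which differs from compound 3 in one place: 3-fluorophenyl in place of 2-methoxyphenyl on a saturated ring carbon.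

Among the measured compounds shown here, only one measured step concerns the group on this saturated ring carbon, namely a 420-fold higher number from compound 2 to compound 3 (2.62 log units; beyond the scatter). For the measured compounds named here, it shows that the group at this place moves the number of this assay strongly, but it compares a 1,3-thiazol-2-yl with a 2-methoxyphenyl, and no measured pair compares two six-membered aromatic rings of carbon only that differ in their substituent. The direction of the step to compound 4 is therefore open. A change is expected, but smaller than that large step; a 2.8-fold lower number from compound 3 to compound 4 (0.45 log units; beyond the scatter) is the estimated step, with a wide range. For compound 4 the expected value in this assay is 150 nM, between 20 nM and 1500 nM.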

Compound 4, half-maximal effective concentration: 512 nM
Compound 4: middle estimate off by 3.4-fold (0.53 log units), on the low side; low and high end bracket the measured number.
By their numbers in this assay, from the lowest: compound 2; then compound 1; then compounds 3 and 4 (each within the scatter of the next).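

In this assay the exchange on the saturated ring carbon gives a 1.2-fold higher number from compound 3 to compound 4 (0.09 log units; within the scatter) and so, for this pair, 2-methoxyphenyl and 3-fluorophenyl cannot be told apart, even though the two groups differ in their substituent and in where it sits. The large distance from the 1,3-thiazol-2-yl group now appears with a second six-membered aromatic ring of carbon only, as a 510-fold higher number from compound 2 to compound 4 (2.71 log units; beyond the scatter) stands alongside a 420-fold higher number from compound 2 to compound 3 (2.62 log units; beyond the scatter) and the low number of compound 2 is thus not set against 2-methoxyphenyl alone. Nothing measured on these groups bears on this result.

With only two substituted phenyl groups at this place, the compounds shown leave open how an unsubstituted phenyl, or a 2-fluorophenyl or 3-methoxyphenyl that would separate the substituent from its location, would stand. Also open, going by these compounds, is whether the low number belongs to the 1,3-thiazol-2-yl group alone or extends to other rings containing nitrogen, such as 1,3-oxazol-2-yl or pyridin-2-yl.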